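A methyl added where the numbers already reach the limit

The source may hold more compounds than are shown below. What is called first, only, known or untested is meant among the compounds shown, and "the series" means these compounds.

Compound 2 `CCOC(=O)c1cn(C[C@H]2O[C@@H](n3ccc(=O)[nH]c3=O)[C@H](SCC)[C@@H]2SCC)nn1` is tested in a functional assay on A549 cells (Homo sapiens) for cytotoxicity, read by MTT assay, with a stated time of 72 h; a lower number here means that less compound is needed, a higher number that more compound is needed for the effect. In this assay compound 2 gives only a limit, >= 100000 nM, not a number. Its neighbours give a sense of scale: compound 1 `CCS[C@@H]1[C@H](SCC)[C@@H](Cn2cc(-c3ccc(C)cc3)nn2)O[C@H]1n1ccc(=O)[nH]c1=O` gives 6780 nM in this assay. Compound 3 `CCS[C@@H]1[C@H](SCC)[C@@H](Cn2cc(COC(C)=O)nn2)O[C@H]1n1ccc(=O)[nH]c1=O` also gives a limit, >= 100000 nM. The measured steps are an at least 14-fold higher number from compound 1 to compound 2 (1.16 log units; beyond the scatter) and an at least 14-fold higher number from compound 1 to compound 3 (1.16 log units; beyond the scatter), while a step that the two limits leave unreadable from compound 2 to compound 3 because of the limit of >= 100000 nM in this assay, at which 2 of the 3 values shown sit.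

Compound 4 `CCOC(=O)c1cn(C[C@H]2O[C@@H](n3cc(C)c(=O)[nH]c3=O)[C@H](SCC)[C@@H]2SCC)nn1` differs from compound 2 by methyl in place of hydrogen on an aromatic carbon. Among the measured compounds shown here, none of the measured steps touches this place; all of them change the group on the other aromatic carbon, so no step beyond the scatter is expected in this assay from this change. Compound 4 is therefore estimated at 100000 nM, between 30000 nM and 300000 nM, which means an expected step of a number no higher from compound 2 to compound 4 (the limit leaves the size open).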

Compound 4, half-maximal effective concentration: >= 100000 nM
Compound 4: a limit, no number (the forecaster's own chance of this, stated with the estimate: 80%); the middle value sits exactly at the limit.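

Compound 2 and compound 4 both give only a limit in this assay, so no step can be read between them: the limit of >= 100000 nM in this assay, at which 3 of the 4 values shown sit.

The compounds shown leave open what methyl in place of hydrogen does in a compound that gives a real number in this assay.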